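Acetyl pyrazoline series: swapping the saturated-carbon aryl group

The source may report more compounds than this note shows. Statements on the series, on what has been measured and on what is new or still open speak of the compounds shown alone.

Compound 1 `COc1ccc(C2OC(c3cc(OC)c(OC)c(OC)c3)=NN2C(C)=O)c(OC)c1` and compound 2 `COc1cc(C2=NN(C(C)=O)C(c3cc(OC)c(OC)c(OC)c3)O2)cc(OC)c1OC` share a core that carries a trimethoxyphenyl group and an acetyl group. In a functional assay on BGC-823 cells (Homo sapiens) for antiproliferative activity, read by MTT assay, tested at 5 uM (on this read-out lower numbers stand for a weaker effect and higher numbers for a stronger effect at the one concentration tested), compound 1 gives -3.1%, a number that lies within the scatter of compound 2 at -1.4%; neither shows an effect at the tested concentration. Compound 3 `COc1cc(C2=NN(C(C)=O)C(c3ccc(F)cc3)O2)cc(OC)c1OC` differs from compound 1 in one place: 4-fluorophenyl in place of 2,4-dimethoxyphenyl on a saturated ring carbon. Going by the values given here, with no measured step to lean on, the change from compound 1 to compound 3 is expected to be small, a number 8.1 percentage points higher from compound 1 to compound 3 (within the scatter), not beyond the scatter. Compound 3 is estimated at 5%, in the range -10% to 25%.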

Compound 3, a percentage reported as inhibition, at one concentration (the size of the read-out at that concentration, not a potency): 13.3%
Estimate against measurement, compound 3: 8.3 percentage points below; the measured number falls inside the stated range.
By their numbers in this assay, from the lowest: compounds 1 and 2 (each within the scatter of the next); then compound 3.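

In this assay, going by these compounds alone, the saturated ring carbon responds to a change of aryl group: 4-fluorophenyl in place of 2,4-dimethoxyphenyl gives a number 16.4 percentage points higher from compound 1 to compound 3 (beyond the scatter) and is the first step read beyond the scatter. The effect remains modest. No evidence at hand explains the step.

Open, from the compounds shown here alone, is whether the step follows the fluorine or the loss of both methoxy groups, as the swap changes both at once. Plain phenyl, 4-methoxyphenyl or 4-aminophenyl on this carbon could separate the two.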